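The source may report more compounds than this note shows. Statements on the series, on what has been measured and on what is new or still open speak of the compounds shown alone.

Measured in a functional assay on ECa-109 cells (Homo sapiens) for antiproliferative activity, read by MTT assay, with a stated time of 48 h; a lower number here means a stronger inhibitor, a higher number a weaker inhibitor:
Compound 1 `CN(C)CCCn1nc(C2=C(c3cn(C)c4ccccc34)C(=O)NC2=O)c2cccnc21` gives > 100000 nM (a limit)
Compound 2 `Cn1cc(C2=C(c3nn(CCCCn4ccnc4)c4ncccc34)C(=O)NC2=O)c2ccccc21` gives 23500 nM
Compound 3 `Cn1cc(C2=C(c3nn(CCn4ccnc4)c4ncccc34)C(=O)NC2=O)c2ccccc21` gives > 100000 nM (a limit)

Compound 3 stands at the limit of > 100000 nM in this assay, at which 2 of the 3 values shown sit, and so has a limit, not a number. Compound 4 `Cn1cc(C2=C(c3nn(CCCO)c4ncccc34)C(=O)NC2=O)c2ccccc21` carries hydroxymethyl in place of 1H-imidazol-1-yl on a saturated chain carbon, two bonds along the chain from an aromatic nitrogen. Among the compounds with values here, no measured step makes this exchange. The nearest readable steps are an at least 4.2-fold lower number from compound 1 to compound 2 (0.62 log units; beyond the scatter) and an at least 4.2-fold higher number from compound 2 to compound 3 (0.62 log units; beyond the scatter), whereas a step that the two limits leave unreadable from compound 1 to compound 3 offers no size. A modest fall is therefore expected in this assay, though another limit remains possible. The expected step is an at least 2.5-fold lower number from compound 3 to compound 4 (0.39 log units; beyond the scatter). For compound 4 the estimated value is 40000 nM, expected to lie between 10000 nM and 100000 nM.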

Compound 4, half-maximal inhibitory concentration: > 100000 nM
Compound 4 was reported as a limit; the forecaster's own chance of this, stated with the estimate: 40%; middle value at least 2.5-fold (0.39 log units) from the limit.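

In this assay, within the data shown here, replacing the 2-(1H-imidazol-1-yl)ethyl end with 3-hydroxypropyl also leaves the compound at a limit, so an imidazole-free chain ending in hydroxy joins the others there: the limit of > 100000 nM in this assay, at which 3 of the 4 values shown sit. Measured against the one compound with a number, the change gives an at least 4.2-fold higher number from compound 2 to compound 4 (0.62 log units; beyond the scatter). The steps that link compound 4 to compound 1 and compound 3 cannot be read, since both ends are limits, so these three compounds cannot be ordered.

As far as these compounds go, whether a 4-hydroxybutyl chain would give a number remains open. So does the effect of a primary amine or a carboxylic acid at the chain end.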